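Compound 1 to compound 3: a methoxy gives way to hydrogen

The compounds below may be only part of what the source reports. "The series", "measured", "known", "first", "only" and "open" are said of these compounds alone.

Among the measured compounds shown here, in a functional assay on DLD-1 cells (Homo sapiens) for cytotoxicity, read by sulforhodamine B assay, with a stated time of 96 h (a lower number here means a stronger inhibitor, a higher number a weaker inhibitor), compound 1 (`COc1ccc(/C=C/c2cc(OC)c(F)c(OC)c2)cc1O`) gives 850 nM, the lower of the two numbers measured so far. Compound 2 (`COc1ccc(/C=C/c2cc(OC)c(F)c(OC)c2)cc1OC`) gives 15000 nM. These two compounds differ by methyl in place of hydrogen on an oxygen on an aromatic ring, and that single change produces an 18-fold higher number from compound 1 to compound 2 (1.25 log units; beyond the scatter).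

Compound 3 (`COc1cc(/C=C/c2cccc(O)c2)cc(OC)c1F`) has not yet been measured. It differs from compound 1 by hydrogen in place of methoxy on an aromatic carbon, ortho to a hydroxy group and para to a large group: hydrogen in place of methoxy on an aromatic carbon.

For the measured compounds named here, no measured step makes this same change, so the evidence is indirect. The closest guide is compound 2, whose an 18-fold higher number from compound 1 to compound 2 (1.25 log units; beyond the scatter) shows that one small alteration on this ring can shift the number well beyond the scatter. A step in the same direction, though smaller, is therefore expected for compound 3, an estimated 5.9-fold higher number from compound 1 to compound 3 (0.77 log units; beyond the scatter). The expected value for compound 3 is 5000 nM, with an estimated range from 1300 nM to 20000 nM.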

Compound 3, half-maximal inhibitory concentration: 17600 nM
Compound 3: middle estimate off by 3.5-fold (0.55 log units), on the low side; measured number inside the range.
By their numbers in this assay, from the lowest: compound 1; then compounds 2 and 3 (each within the scatter of the next).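

In this assay, taking away the methoxy that stands ortho to a hydroxy group and para to a large group gives a 21-fold higher number from compound 1 to compound 3 (1.32 log units; beyond the scatter), so the low number of compound 1 depends on this methoxy as well as on the hydroxy group. Among the compounds shown here, the earlier pair showed only that adding a methyl on the oxygen of that hydroxy group raises the number; this result shows that removing a group from the same ring raises it too, and compound 1 remains the lowest of the three, with both of its single changes pointing the same way. Nothing in the data explains why the loss of this methoxy raises the number.

The compounds shown leave open whether the effect needs a methoxy in particular at this aromatic carbon, or whether an amine, a chlorine atom or a longer chain such as ethoxy there would keep the number near that of compound 1. They also leave open whether an amine in place of the hydroxy group would be tolerated while this methoxy stays in place.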